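Sulfamoyl in Place of Nitro: From Compound 2 to Compound 4

This account rests on a few compounds, and the source may have more. Where it says the series, first, only, none or still open, it means among the compounds named here.

Of the compounds shown here, three built on one shared core have been measured in a functional assay on WiDr cells (Homo sapiens) for inhibition; a higher number here means a weaker inhibitor, a lower number a stronger inhibitor. In this assay compound 1 `CCCCNC(=O)N1CC1C#N` gives 18000 nM, and compound 3 `N#CC1CN1C(=O)NC1CCCCC1` gives 12000 nM. Compound 2 `N#CC1CN1C(=O)Nc1ccc([N+](=O)[O-])cc1` gives 3700 nM, the lowest of the three numbers; its gaps to compound 3 and to compound 1 both lie beyond the scatter, so compound 2 stands as the strongest inhibitor of the set.

Compound 4 `N#CC1CN1C(=O)Nc1ccc(S(N)(=O)=O)cc1` differs from compound 2 in a single place: sulfamoyl in place of nitro on an aromatic carbon. For the measured compounds named here, no measured pair shows this exact exchange, so the size of its step is not known from the data at hand. The replacement keeps the overall shape of compound 2 and introduces one hydrogen-bond donor, and the expectation is a step of a 1.4-fold higher number from compound 2 to compound 4 (0.13 log units; within the scatter), lying within or only just beyond the scatter, with no clear direction favoured. Compound 4 is accordingly estimated at 5000 nM in this assay, with a range from 1500 nM to 17000 nM.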

Compound 4, half-maximal inhibitory concentration: > 38000 nM
Compound 4: only a limit was reported; the forecaster's own chance of this, stated with the estimate: 5%; at least 7.6-fold (0.88 log units) between middle value and limit.
By their numbers in this assay, from the lowest: compound 2; then compounds 3 and 1 (each within the scatter of the next). At a limit, above all of these: compound 4.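

In this assay compound 4 is recorded only as a limit, > 38000 nM. Until now the compounds shown held no exchange at this aromatic carbon, and sulfamoyl in place of nitro now gives an at least 10-fold higher number from compound 2 to compound 4 (1.01 log units; beyond the scatter), so this position is far from indifferent to the group it carries and nitro cannot be exchanged for sulfamoyl here without a clear loss of inhibition. How large the loss really is cannot be read, because the value of compound 4 is only a limit: the limit of > 38000 nM in this assay, at which 1 of the 4 values shown sits.

The compounds shown leave open whether a methylsulfonyl group, an amine or a carboxylic acid on this same aromatic carbon would stay close to compound 2 or fall away as compound 4 does. They also leave open whether the same exchange would cost as much with a cyclohexyl or butyl chain in place of the aromatic ring.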